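Swapping 4-Aminophenyl for (Methoxycarbonyl)methyl: a Limit Expected

The source may hold more compounds than are shown below. What is called first, only, known or untested is meant among the compounds shown, and "the series" means these compounds.

The set holds three compounds with reported outcomes and one awaiting measurement. Compound 1 `N[C@H]1CC[C@H](Nc2c(C(=O)NCc3ccc(F)cc3)nc(N3CCCCC3)c3cccnc23)CC1` appears in the series, yet for compound 1 the outcome in a functional assay on HT-29 cells (Homo sapiens) for cytotoxicity, read by MTT assay, with a stated time of 72 h (a higher number here means a weaker inhibitor, a lower number a stronger inhibitor), is "not determined" (no result reported). Compound 2 `Nc1ccc(Nc2c(C(=O)NCc3ccc(F)cc3)nc(Br)c3cccnc23)cc1` reaches only the limit of the assay: in this assay compound 2 gives > 10000 nM, a limit and not a number. Compound 3 `NCCCNc1c(C(=O)NCc2ccc(F)cc2)ncc2cccnc12` likewise stops at a limit, giving in this assay > 10000 nM for compound 3. Where compound 2 stands is therefore a floor rather than a position on a scale: it sits at the limit of > 10000 nM in this assay, at which 2 of the 3 values shown sit, and no step between two measured compounds exists against which its standing could be weighed.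

Compound 4 `COC(=O)CNc1c(C(=O)NCc2ccc(F)cc2)nc(Br)c2cccnc12` differs from compound 2 by (methoxycarbonyl)methyl in place of 4-aminophenyl on a nitrogen on an aromatic ring.

For the measured compounds named here, with no measured step to lean on, the expected step from compound 2 to compound 4 is a step that the limit leaves unreadable from compound 2 to compound 4, which amounts to no movement beyond the usual scatter, because compound 2 already rests at the limit of > 10000 nM in this assay, at which 2 of the 3 values shown sit. The estimate for compound 4 in this assay is 15000 nM, with a range from 4000 nM to 60000 nM, and the likeliest report for compound 4 is again only a limit.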

Compound 4, half-maximal inhibitory concentration: > 10000 nM
Compound 4: a limit, no number; the forecaster's own chance of this, stated with the estimate: 75%; the middle value lies beyond the limit too.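

In this assay compound 4 gives > 10000 nM, a limit and not a number. Compound 2 also rests at a limit, so no step can be read between compound 2 and compound 4: the limit of > 10000 nM in this assay, at which 3 of the 4 values shown sit.

The compounds shown leave open how strongly any of them acts in this assay, and whether (methoxycarbonyl)methyl and 4-aminophenyl on that nitrogen differ there at all.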